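Trifluoromethyl Step on an Already Non-Cytotoxic Core

This account rests on a few compounds, and the source may have more. Where it says the series, first, only, none or still open, it means among the compounds named here.

Compound 2 `FC(F)(F)c1ccc(NCc2cn(-c3ccccc3)nc2-c2ccccc2)cc1` and compound 1 `FC(F)(F)c1ccc(NCc2cn(-c3ccccc3)nc2-c2ccc(C(F)(F)F)cc2)cc1` share one core and differ only in trifluoromethyl in place of hydrogen on an aromatic carbon. Both were tested in an ADME assay on MT4 cells (Homo sapiens) for cytotoxicity, read by MTT assay, with a stated time of 96 h; on this read-out lower numbers stand for higher toxicity in this test and higher numbers for lower toxicity in this test. In this assay compound 2 gives > 100000 nM, which is a limit of the assay rather than a number. Compound 1 gives > 100000 nM in this assay, again a limit. The resulting step is a step that the two limits leave unreadable from compound 2 to compound 1. Compound 3 `Cc1ccc(-c2nn(-c3ccccc3)cc2CNc2ccccc2)cc1` rests on a different core; the difference between the two cores is not broken down here. In this assay compound 3 gives > 100000 nM, once more a limit. Compound 4 `Cc1ccc(-c2nn(-c3ccccc3)cc2CNc2ccc(C(F)(F)F)cc2)cc1` is compound 3 with trifluoromethyl in place of hydrogen on an aromatic carbon, the same change as between compound 2 and compound 1, at a place described in the same words. Because (the limit of > 100000 nM in this assay, at which 3 of the 3 values shown sit), compound 4 is expected to remain at that limit, so the expected step is a step that the limit leaves unreadable from compound 3 to compound 4. The estimate for compound 4 in this assay is 150000 nM, with an expected range from 80000 nM to 300000 nM, and most likely the assay will again report only a limit.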

Compound 4, half-maximal cytotoxic concentration: > 100000 nM
Compound 4 was reported as a limit (the forecaster's own chance of this, stated with the estimate: 85%); the middle value does not contradict the limit.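

Among the compounds shown here, no step among compound 1, compound 2, compound 3 and compound 4 can be read in this assay, and the new result adds no size to any comparison: the limit of > 100000 nM in this assay, at which 4 of the 4 values shown sit. The compounds shown leave open how far each lies beyond that limit, and whether the trifluoromethyl or methyl changes alter cytotoxicity at all.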